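From Thiophene to Dimethylpyrazole on a Shared Core

A few compounds are considered here, and "the series" means these few. Any claim that something is new, unique, unknown or untested is made for them only; others in the source may bear on it.

compound 1 `CCOC(=O)c1cnc(C(C)(C)C)nc1NN1C(=O)C=C(C)C1=O` — 1000 nM
compound 2 `CCOC(=O)c1cnc(-c2ccccc2)nc1NN1C(=O)C=C(C)C1=O` — 100 nM
compound 3 `CCOC(=O)c1cnc(-c2cccs2)nc1NN1C(=O)C=C(C)C1=O` — 20 nM

In a functional assay on Jurkat cells for inhibition of nuclear factor NF-kappa-B complex (Homo sapiens) (on this read-out lower numbers stand for stronger inhibition and higher numbers for weaker inhibition), compound 3 gives the lowest number of the three measured compounds. The nearest neighbour is set by a 5.0-fold lower number from compound 2 to compound 3 (0.70 log units; beyond the scatter), the furthest by a 50-fold lower number from compound 1 to compound 3 (1.70 log units; beyond the scatter). Compound 4 `CCOC(=O)c1cnc(-n2nc(C)cc2C)nc1NN1C(=O)C=C(C)C1=O` differs from compound 3 in one place: 3,5-dimethyl-1H-pyrazol-1-yl in place of thiophen-2-yl on an aromatic carbon. Among the compounds with values here, no measured step swaps one five-membered ring for another, so the expectation rests on the steps that changed this same group, a 10-fold lower number from compound 1 to compound 2 (1.00 log units; beyond the scatter) and a 5.0-fold lower number from compound 2 to compound 3 (0.70 log units; beyond the scatter), each of which moved this assay beyond the scatter. A change of similar size is therefore expected here, and since compound 3 already stands lowest, the estimated direction is upward: a 5.0-fold higher number from compound 3 to compound 4 (0.70 log units; beyond the scatter). Compound 4 is expected to give about 100 nM, within a range of 20 nM to 500 nM.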

Compound 4, half-maximal inhibitory concentration: 10000 nM
Compound 4: middle estimate off by 100-fold (2.00 log units), on the low side; the whole stated range lies below it.
By their numbers in this assay, from the lowest: compound 3; then compound 2; then compound 1; then compound 4.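

At this position on the shared core, a five-membered aromatic ring does not by itself keep the number low in this assay: swapping thiophen-2-yl for 3,5-dimethyl-1H-pyrazol-1-yl gives (a 500-fold higher number from compound 3 to compound 4 (2.70 log units; beyond the scatter)). The same group also compares poorly with phenyl (a 100-fold higher number from compound 2 to compound 4 (2.00 log units; beyond the scatter)) and with tert-butyl (a 10-fold higher number from compound 1 to compound 4 (1.00 log units; beyond the scatter)), so compound 4 has the highest number of the four. No measurement shown accounts for this rise. Still open, on these data alone, is how a plain pyrazol-1-yl or a furan-2-yl would read here, which would help separate the two methyl groups from the ring itself.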